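A Halogenated Phenyl Swap Repeated on a Second Core

This account rests on a few compounds, and the source may have more. Where it says the series, first, only, none or still open, it means among the compounds named here.

Compound 1 `CCOCCOC(=O)C(=O)Nc1nc(-c2c(-c3ccccc3)noc2C)cs1` and compound 2 `CCOCCOC(=O)C(=O)Nc1nc(-c2c(-c3c(F)cccc3Cl)noc2C)cs1` share one core, while compound 3 `O=C(O)C(=O)Nc1nc(-c2conc2-c2ccccc2)cs1` carries a different one; the difference between the two cores is not broken down here. All three were tested in a functional assay on the whole organism with Rattus norvegicus as the target; on this read-out lower numbers stand for an effect already at smaller amounts and higher numbers for an effect only at larger amounts of compound. In this assay compound 1 gives only a limit, > 100 mg/kg. In this assay compound 2 likewise gives only a limit, > 30 mg/kg. In this assay compound 3 also gives only a limit, > 100 mg/kg.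

The change from compound 1 to compound 2 is 2-chloro-6-fluorophenyl in place of phenyl on an aromatic carbon. Its size is a step that the two limits leave unreadable from compound 1 to compound 2, which cannot be read because both ends are limits: the limit of > 100 mg/kg in this assay, at which 2 of the 3 values shown sit, and (the limit of > 30 mg/kg in this assay, at which 1 of the 3 values shown sits).

Compound 4 `O=C(O)C(=O)Nc1nc(-c2conc2-c2c(F)cccc2Cl)cs1` has not yet been measured. The change from compound 3 to compound 4 is 2-chloro-6-fluorophenyl in place of phenyl on an aromatic carbon, the same kind of change as from compound 1 to compound 2, but not the same: around the place on the core of compound 1 the change also stands two ring bonds from the ring atom that bears a methyl group, whereas on the core of compound 3 it does not.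

For the measured compounds named here, the expected step from compound 3 to compound 4 is a number no higher from compound 3 to compound 4 (the limit leaves the size open), since the only measured instance of this kind of change, a step that the two limits leave unreadable from compound 1 to compound 2, is unreadable and every value shown sits at a limit. The estimated value of compound 4 in this assay is therefore 100 mg/kg, expected to lie between 30 mg/kg and 300 mg/kg.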

Compound 4, dose for half-maximal effect: > 100 mg/kg
Compound 4 gave a limit, no number; the forecaster's own chance of this, stated with the estimate: 80%; the middle value sits exactly at the limit.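

In this assay compound 4 gives only a limit, > 100 mg/kg. For the compounds shown here, compound 3 also gives only a limit, so no step between compound 3 and compound 4 can be read. The compounds shown leave open whether 2-chloro-6-fluorophenyl in place of phenyl makes any difference in this assay on either core, and how the two cores compare.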